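A few compounds are considered here, and "the series" means these few. Any claim that something is new, unique, unknown or untested is made for them only; others in the source may bear on it.

Compound 2 `Cc1cc(-c2cccc([N+](=O)[O-])c2)c2ncc(CSCCc3ccccc3)n2c1` gives 100 ug/mL in an ADME assay on HEL cells (Homo sapiens) for cytotoxicity, with a stated time of 3 days (on this read-out higher numbers stand for lower toxicity in this test and lower numbers for higher toxicity in this test), level with compound 1 `Cc1cc(-c2ccsc2)c2ncc(CSCCc3ccccc3)n2c1`, which gives 100 ug/mL. The step of no change at the digits printed from compound 1 to compound 2 (within the scatter) shows that exchanging one aromatic group for another on an aromatic carbon left the read-out where it was. Compound 3 `COc1cccc(-c2cc(C)cn3c(CSCCc4ccccc4)cnc23)c1` differs from compound 2 by methoxy in place of nitro on an aromatic carbon. Going by the values given here, only that one measured step bears on this change, and it lay within the scatter, so no step beyond the scatter is expected in no change at the digits printed from compound 2 to compound 3 (within the scatter). Compound 3 is therefore estimated at 100 ug/mL, with a range from 50 ug/mL to 200 ug/mL.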

Compound 3, minimum cytotoxic concentration: 100 ug/mL
Beside the measured number, compound 3's estimate shows no gap at the digits printed, within the range that was stated.
By their numbers in this assay, from the lowest: compounds 1, 2 and 3 (each within the scatter of the next).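

Methoxy in place of nitro (no change at the digits printed from compound 2 to compound 3 (within the scatter)) and 3-methoxyphenyl in place of thiophen-3-yl (no change at the digits printed from compound 1 to compound 3 (within the scatter)) both read the same in this assay. A second substituent on this phenyl ring, and so a third aromatic group on the core, therefore gives the same read-out as the earlier two. Nothing measured here offers a reason for this. The compounds shown leave open whether an amine or a carboxylic acid in this place on the ring would also read the same.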